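A few compounds are considered here, and "the series" means these few. Any claim that something is new, unique, unknown or untested is made for them only; others in the source may bear on it.

Measured so far: compound 1 `N#Cc1c(Nc2ccccc2F)nc(SCc2cn(Cc3ccccc3Cl)nn2)nc1-c1ccccc1`; compound 2 `Cc1ccc(Cn2cc(CSc3nc(Nc4ccccc4C)c(C#N)c(-c4ccccc4)n3)nn2)cc1`; compound 3 `N#Cc1c(Nc2ccccc2F)nc(SCc2cn(Cc3ccc(Cl)cc3)nn2)nc1-c1ccccc1`.

In a functional assay on ECa-109 cells (Homo sapiens) for inhibition, read by MTT assay, with a stated time of 72 h (a higher number here means a weaker inhibitor, a lower number a stronger inhibitor), compound 1 gives 23000 nM. In this assay compound 2 gives > 64000 nM, a limit of the assay rather than a number. In this assay compound 3 gives > 64000 nM, again only a limit. Compound 3 thus sits at the limit of > 64000 nM in this assay, at which 2 of the 3 values shown sit, and the step of an at least 2.7-fold higher number from compound 1 to compound 3 (0.44 log units; beyond the scatter) shows how far it falls short of compound 1.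

Compound 4 `Cc1ccc(Cn2cc(CSc3nc(Nc4ccccc4F)c(C#N)c(-c4ccccc4)n3)nn2)cc1` differs from compound 3 by methyl in place of chloro on an aromatic carbon. Within the data shown here, no measured step covers chloro to methyl; the values bearing on it are those of compound 2 and compound 3, both limits. Compound 4 is therefore expected to remain at the limit, a number no higher from compound 3 to compound 4 (the limit leaves the size open). The estimate for compound 4 is 64000 nM, range 25000 nM to 250000 nM.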

Compound 4, half-maximal inhibitory concentration: > 64000 nM
Compound 4: no number, only a limit; the forecaster's own chance of this, stated with the estimate: 75%; the middle value sits exactly at the limit.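

In this assay, methyl on this aromatic carbon, like chloro, leaves the series without a readable number, and the 4-methylphenyl group in place of 2-chlorophenyl gives an at least 2.7-fold higher number from compound 1 to compound 4 (0.44 log units; beyond the scatter). The steps from compound 3 and from compound 2 to compound 4 cannot be read, as both ends of each are limits. Compound 4 adds one more value at that limit: the limit of > 64000 nM in this assay, at which 3 of the 4 values shown sit.

Going by these compounds, the size of any difference between methyl and chloro at this place stays open. Also open, on these data alone, is whether an amine or a carboxylic acid on this aromatic carbon would give a readable number.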